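Chain extension on the aryl substituent of a cyclohexyl-imidazolone core

The compounds below may be only part of what the source reports. "The series", "measured", "known", "first", "only" and "open" are said of these compounds alone.

Compound 1 `CCCCc1ccc(-c2c(C)[nH]c(=O)n2C2CCCCC2)cc1` gives 27100 nM in a functional assay on brain (Rattus norvegicus, strain Wistar) for inhibition; on this read-out higher numbers stand for weaker inhibition and lower numbers for stronger inhibition. Compound 2 `CCCCCCc1ccc(-c2c(C)[nH]c(=O)n2C2CCCCC2)cc1`, which carries the change (ethyl in place of hydrogen on a saturated chain carbon, four bonds along the chain from an aromatic carbon), gives 13700 nM in this assay, so a 2.0-fold lower number from compound 1 to compound 2 (0.30 log units; within the scatter). Compound 3 `CCCCCCCCCCOc1ccc(-c2c(C)[nH]c(=O)n2C2CCCCC2)cc1` gives 10500 nM in this assay; the difference between the core of compound 3 and the core of compound 1 is not broken down here. The value of compound 3 lies within the scatter of that of compound 2, and below that of compound 1 by a gap beyond the scatter.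

Compound 4 `CCCCCCCCCCCCOc1ccc(-c2c(C)[nH]c(=O)n2C2CCCCC2)cc1` is not yet measured in this assay. It differs from compound 3 by ethyl in place of hydrogen on a saturated chain carbon, ten or more bonds along the chain from an oxygen on an aromatic ring, the same kind of change as ethyl in place of hydrogen on a saturated chain carbon, four bonds along the chain from an aromatic carbon, though placed differently along the chain. Resting on the single earlier step, a 2.0-fold lower number from compound 1 to compound 2 (0.30 log units; within the scatter), the estimated step is a 1.4-fold lower number from compound 3 to compound 4 (0.15 log units; within the scatter), kept small because a 2.0-fold lower number from compound 1 to compound 2 (0.30 log units; within the scatter) itself sits within the scatter. Compound 4 is expected to give about 7500 nM in this assay, between 3500 nM and 16000 nM.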

Compound 4, half-maximal inhibitory concentration: 52400 nM
Compound 4: the middle estimate sits 7.0-fold (0.84 log units) below what was measured; measured number above the stated range.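

In this assay, the change of ethyl in place of hydrogen does not carry over as one fixed step from the core of compound 1 to the core of compound 3, and the new step, a 5.0-fold higher number from compound 3 to compound 4 (0.70 log units; beyond the scatter), runs opposite to the earlier one by more than two such steps would scatter: the same change on two cores in this assay, a 2.0-fold lower number (0.30 log units; within the scatter) from compound 1 to compound 2 and a 5.0-fold higher number (0.70 log units; beyond the scatter) from compound 3 to compound 4, 9.9-fold (0.99 log units) apart, beyond the scatter of two such steps

Only the new step lies beyond the scatter, so the contrast is between a clear rise in the number and an earlier step that cannot be told from no change. One pair on each core does not show why the two steps part, nor whether the change would behave the same way at other places along the chain.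

Still open, on these data alone, is whether a longer chain on the oxygen-linked core would continue the rise seen at compound 4. Also open, as far as these compounds go, is how a carboxylic acid or an amine at the chain end would read on either core.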